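The compounds below may be only part of what the source reports. "The series", "measured", "known", "first", "only" and "open" are said of these compounds alone.

Measured in a functional assay on HCT-116 cells (Homo sapiens) for inhibition, read by luminescence and resazurin assay, with a stated time of 3 days; on this read-out higher numbers stand for weaker inhibition and lower numbers for stronger inhibition:

compound 1 `O=S(=O)(Nc1ccc(CNc2nc(NC3CC3)nc3ccccc23)cc1)c1ccc(F)cc1`: 4900 nM
compound 3 `O=C(Nc1ccc(F)cc1)c1ccc(CNc2nc(NC3CC3)nc3ccccc23)cc1`: 2700 nM
compound 2 `CCNc1ncc(C)c(NCc2ccc(NC(=O)c3ccc(F)cc3)cc2)n1`: > 20000 nM, which is a limit of the assay and not a number (the limit of > 20000 nM in this assay, at which 1 of the 3 values shown sits)

Compound 3 stands at the lowest of the two numbers shown. Its nearest neighbour is compound 1, and the step of a 1.8-fold lower number from compound 1 to compound 3 (0.26 log units; within the scatter) lies within the scatter, so the two are not separated by this assay. Compound 2 contributes only a limit.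

Compound 4 `C=CCNc1nc(NCc2ccc(C(=O)Nc3ccc(F)cc3)cc2)c2ccccc2n1` has not yet been measured in this assay. It differs from compound 3 in one place: allyl in place of cyclopropyl on a nitrogen on an aromatic ring. Within the data shown here, no measured step touches this part of the shared core. Among the measured compounds shown here, the single measured step, a 1.8-fold lower number from compound 1 to compound 3 (0.26 log units; within the scatter), concerns the other end of the molecule and is itself within the scatter. For the measured compounds named here, the two structures carry the same atoms joined differently, and nothing among the measured compounds points to a step beyond the scatter in this assay in either direction.

The step from compound 3 to compound 4 is therefore expected to be about a 1.1-fold higher number from compound 3 to compound 4 (0.05 log units; within the scatter), a change not resolvable from the scatter. Compound 4 is expected to give roughly 3000 nM in this assay, within a range of 1000 nM to 10000 nM.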

Compound 4, half-maximal inhibitory concentration: 14000 nM
Compound 4: the middle estimate sits 4.7-fold (0.67 log units) below what was measured; the whole stated range lies below it.
By their numbers in this assay, from the lowest: compounds 3 and 1 (each within the scatter of the next); then compound 4. At a limit, above all of these: compound 2.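

In this assay, among these compounds, the substituent on the nitrogen on an aromatic ring of the shared core is the first place where a single change gives a step beyond the scatter: a 5.2-fold higher number from compound 3 to compound 4 (0.71 log units; beyond the scatter) in the direction of weaker inhibition. Among the compounds shown here, the only earlier step, a 1.8-fold lower number from compound 1 to compound 3 (0.26 log units; within the scatter), changed a different part of the molecule and did not separate its two compounds, so this position responds to a change that the counts barely register: cyclopropylamino to allylamino keeps the same atoms and the same number of hydrogen-bond donors and acceptors, and swaps a three-membered ring for an open chain with a double bond. No measured property in the data bears on the reason for this step.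

The step cannot yet be assigned to the loss of the ring or to the presence of the double bond, and a saturated propyl chain or a cyclobutyl group on the same nitrogen would separate the two. From the compounds shown here alone, it also remains open how far this position tolerates larger or more polar substituents, such as a longer alkyl chain or a hydroxyethyl group.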